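Inverting One Ring Stereocentre: Compound 1 to Compound 3

A few compounds are considered here, and "the series" means these few. Any claim that something is new, unique, unknown or untested is made for them only; others in the source may bear on it.

Measured so far:
- compound 1 `FC(F)(F)CCCSc1nsnc1[C@H]1CN2CCC[C@@H]1C2`: 1.8 mg/kg
- compound 2 `CCCCCCSc1nccnc1C1CN2CCC1CC2`: 2.3 mg/kg

In a functional assay on the whole organism with Mus musculus as the target, in the writhing test (on this read-out lower numbers stand for an effect already at smaller amounts and higher numbers for an effect only at larger amounts of compound), compound 1 gives 1.8 mg/kg and compound 2 gives 2.3 mg/kg. For the measured compounds named here, these two numbers lie within the usual scatter of each other, so they set no order between the compounds.

Compound 3 `FC(F)(F)CCCSc1nsnc1[C@@H]1CN2CCC[C@@H]1C2` has not yet been measured. Its structure differs from that of compound 1 as follows: the two compounds have the same atoms and bonds; at least one stereo element is drawn with a configuration in one of them and without one in the other: 1 of 3 stereo elements differ; a stereocentre at a saturated ring carbon is drawn R in compound 1 and S in compound 3. The two compounds have the same atoms and bonds, and a stereocentre at a saturated ring carbon is drawn R in compound 1 and S in compound 3.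

Going by the values given here, no measured pair shows what such an inversion does, so the expectation rests on compound 1 at 1.8 mg/kg alone and stays loose. A moderate move toward a higher number in this assay is expected, though a result within the scatter of compound 1 would not be surprising. The expected size is a 2.2-fold higher number from compound 1 to compound 3 (0.35 log units; beyond the scatter). For compound 3 the estimated value is 4 mg/kg, with an expected range of 0.9 mg/kg to 20 mg/kg.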

Compound 3, dose for half-maximal effect: 0.35 mg/kg
Estimate against measurement, compound 3: 11-fold (1.06 log units) above; the measured number lies below the stated range.
By their numbers in this assay, from the lowest: compound 3; then compounds 1 and 2 (each within the scatter of the next).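

In this assay, the configuration at one saturated ring carbon is enough on its own to shift the read-out: with atoms and bonds unchanged, going from R to S gives a 5.1-fold lower number from compound 1 to compound 3 (0.71 log units; beyond the scatter). This is the first comparison in the series between compounds that differ in one place, and the first step shown to lie beyond the scatter, whereas compound 1 and compound 2 set no order between them; this stereocentre is therefore a place where the read-out responds to a change, and S gives the lower number of the two drawn forms. The step carries one reservation, which rests on how the two structures are drawn: the fact that one of compounds 1 and 3 is drawn with a defined configuration and the other without, at the place where they differ

On these data alone, the other two stereo elements are the same in compound 1 and compound 3, so what each contributes to the read-out remains open. Also open, as far as these compounds go, is whether the same inversion gives a step of similar size when the trifluoromethyl is replaced by another group, such as a nitrile or a carboxylic acid.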